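A few compounds are considered here, and "the series" means these few. Any claim that something is new, unique, unknown or untested is made for them only; others in the source may bear on it.

Three analogues share one core. Compound 1 `Cc1ccccc1Nc1nc(Nc2cccnc2)ncc1Cl` gives 38600 nM in a functional assay on Jurkat cells (Homo sapiens) for inhibition, read by CCK-8 assay, with a stated time of 48 h; on this read-out lower numbers stand for stronger inhibition of growth and higher numbers for weaker inhibition of growth. Compound 2 `Cc1ccccc1Nc1nc(NC2CCCCC2)ncc1Cl` stands only at the limit > 100000 nM in this assay. Compound 3 `Cc1ccccc1Nc1nc(NCc2ccccc2)ncc1Cl` likewise reaches only the limit > 100000 nM in this assay, so no number is known for it, and two of the three values sit at that limit (the limit of > 100000 nM in this assay, at which 2 of the 3 values shown sit). Compound 4 `Cc1ccccc1Nc1nc(Nc2cc(Cl)ccn2)ncc1Cl` differs from compound 3 by 4-chloropyridin-2-yl in place of benzyl on a nitrogen on an aromatic ring. Among the compounds with values here, the steps that bear on this are an at least 2.5-fold higher number from compound 1 to compound 2 (0.41 log units; beyond the scatter) and an at least 2.5-fold higher number from compound 1 to compound 3 (0.41 log units; beyond the scatter), both moving away from an aromatic ring with a hetero atom; the step that the two limits leave unreadable from compound 2 to compound 3 is unreadable. For compound 4 a step of an at least 2.5-fold lower number from compound 3 to compound 4 (0.39 log units; beyond the scatter) toward stronger inhibition is expected, back toward the standing of compound 1 at 38600 nM. Compound 4 is estimated at 40000 nM in this assay, between 12000 nM and 130000 nM.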

Compound 4, concentration for 50% growth inhibition: 39600 nM
Compound 4: the middle estimate sits 1.0-fold (0.00 log units) above what was measured; the range from low to high includes it.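

In this assay, 4-chloropyridin-2-yl on this nitrogen gives an at least 2.5-fold lower number from compound 3 to compound 4 (0.40 log units; beyond the scatter) and an at least 2.5-fold lower number from compound 2 to compound 4 (0.40 log units; beyond the scatter), so a ring with a hetero atom here is not limited to the pyridin-3-yl of compound 1. Against that pyridin-3-yl, the change gives a 1.0-fold higher number from compound 1 to compound 4 (0.01 log units; within the scatter), so the two rings cannot be told apart in this read-out. Compound 2 and compound 3 each stand at a limit, so those two steps are bounds only: the limit of > 100000 nM in this assay, at which 2 of the 4 values shown sit.

On these data alone, it stays open what the chlorine contributes. Also open, as far as these compounds go, is whether an unsubstituted pyridin-2-yl or a phenyl group on this nitrogen would stand with compound 1 and compound 4 or at the limit.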